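A few compounds are considered here, and "the series" means these few. Any claim that something is new, unique, unknown or untested is made for them only; others in the source may bear on it.

The measured compounds in a functional assay, with a stated time of 150 min (a higher number here means a weaker inhibitor, a lower number a stronger inhibitor), are:
compound 1 `CCOC(=O)c1cnn(-c2nc(-c3ccccc3F)c(C#N)c(=O)n2C)c1N` with 87 ug/mL
compound 2 `CCOC(=O)c1cnn(-c2nc(-c3ccccc3O)c(C#N)c(=O)n2C)c1N` with 64 ug/mL
compound 3 `CCOC(=O)c1cnn(-c2nc(-c3ccco3)c(C#N)c(=O)n2C)c1N` with 108 ug/mL

Compound 3 gives the highest of the three numbers, but its distance to the others is small: the steps of a 1.2-fold higher number from compound 1 to compound 3 (0.09 log units; within the scatter) and a 1.7-fold higher number from compound 2 to compound 3 (0.23 log units; within the scatter) are both within the scatter, so compound 3 cannot be separated from compound 1 or compound 2 on these values. All three share one core and differ only in the aromatic group attached to it.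

Compound 4 `CCOC(=O)c1cnn(-c2nc(-c3ccccc3Cl)c(C#N)c(=O)n2C)c1N` has not yet been measured. Its change from compound 3 is 2-chlorophenyl in place of furan-2-yl on an aromatic carbon. Within the data shown here, two measured steps bear on this change. The step of a 1.2-fold higher number from compound 1 to compound 3 (0.09 log units; within the scatter) covers the reverse exchange of a 2-fluorophenyl for the furan-2-yl, and the step of a 1.4-fold lower number from compound 1 to compound 2 (0.13 log units; within the scatter) shows that swapping the fluoro of compound 1 for a hydroxy also moved the number only within the scatter. Since both steps were small, a 2-chlorophenyl is expected to give a number close to that of compound 1, and the step of a 1.4-fold lower number from compound 3 to compound 4 (0.13 log units; within the scatter) is expected to stay within the scatter. Compound 4 is therefore estimated at 80 ug/mL, with a range from 45 ug/mL to 150 ug/mL.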

Compound 4, half-maximal inhibitory concentration: 93 ug/mL
For compound 4 the middle estimate is 1.2-fold (0.07 log units) below the measured one, and the stated range covers the measured number.
By their numbers in this assay, from the lowest: compounds 2, 1, 4 and 3 (each within the scatter of the next).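

In this assay the exchange at the aromatic carbon ortho to a cyano group now covers a second pairing of a five-membered aromatic ring with a hetero atom and a six-membered aromatic ring of carbon only: 2-chlorophenyl in place of furan-2-yl gives a small step (a 1.2-fold lower number from compound 3 to compound 4 (0.06 log units; within the scatter)) that stays within the scatter. Compound 4 also adds a third substituent on the phenyl group, and neither chloro in place of fluoro (a 1.1-fold higher number from compound 1 to compound 4 (0.03 log units; within the scatter)) nor chloro in place of hydroxy (a 1.5-fold higher number from compound 2 to compound 4 (0.16 log units; within the scatter)) separates the compounds, so every group shown at this position gives a number within the scatter of the others. No supporting data bear on the reason for this closeness.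

The compounds shown leave open whether the position stays this insensitive when the aromatic group gives way to an amine, a carboxylic acid or a longer alkyl chain. They also leave open what a methoxy group on the phenyl ring would give, or what changes to the ethyl ester of the shared core would do to the number.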